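From 3,4-Difluorophenyl to Cyclopropyl: An Open Question

The compounds below may be only part of what the source reports. "The series", "measured", "known", "first", "only" and "open" are said of these compounds alone.

In an ADME assay on microsomes from liver (Rattus norvegicus) for metabolic stability, read by LC-MS, with a stated time of 30 min, tested at 0.1 uM (a higher number here means that more of the compound is left, a lower number that less of the compound is left), compound 1 `Fc1ccc(-c2nc3cnc(Nc4ccc(C(F)(F)F)cn4)cc3[nH]2)cc1F` gives 89%, and compound 2 `Fc1ccc(Nc2cc3[nH]c(-c4ccc(F)c(F)c4)nc3cn2)nc1` gives 79%. Among the compounds with values here, these are the only two measured values so far, and they lie within the usual scatter of each other, so compound 1 cannot be separated from compound 2 on these numbers.

Compound 3 `FC(F)(F)c1ccc(Nc2cc3[nH]c(C4CC4)nc3cn2)nc1` has not yet been measured. It keeps the trifluoromethyl group of compound 1 but carries cyclopropyl in place of 3,4-difluorophenyl on an aromatic carbon.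

Within the data shown here, only one measured step offers any guidance, and it concerns a different group: a number 10 percentage points lower from compound 1 to compound 2 (within the scatter). That step shows one change to compound 1 that stayed within the scatter, but it says little about the present swap. Among the measured compounds shown here, no measurement yet tests a change at the place where cyclopropyl enters, so the data give no firm direction. No step beyond the scatter is therefore expected, although the uncertainty is wide. The estimated change is a number 7 percentage points lower from compound 1 to compound 3 (within the scatter). Compound 3 is expected at 82%, with an estimated range from 60% to 96%.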

Compound 3, percent of the compound remaining: 96%
The estimate for compound 3 lay 14 percentage points below the measured number; the measured number falls inside the stated range.
By their numbers in this assay, from the lowest: compounds 2, 1 and 3 (each within the scatter of the next, the first and the last beyond it).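

In this assay, within the data shown here, the first measured change at this position, cyclopropyl in place of 3,4-difluorophenyl, gives a number 7 percentage points higher from compound 1 to compound 3 (within the scatter). The earlier step changed only the group on the other side of the molecule, whereas this one shows that the aromatic carbon between two ring nitrogen atoms can carry either a six-membered aromatic ring of 8 heavy atoms or a three-membered non-aromatic ring of 3 heavy atoms, with no difference that stands clear of the scatter. Nothing measured here explains this outcome or links it to any feature of either group.

From the compounds shown here alone, the two groups seen at this position both contain rings of carbon only, so it remains open whether an amine, a carboxylic acid or a longer carbon chain at the same carbon would also stay within the scatter of compound 1. Going by these compounds, it is also open whether cyclopropyl would give a similar result when paired with the fluoro group of compound 2 instead of trifluoromethyl.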